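Notes on three measured compounds and an expected fourth

This account rests on a few compounds, and the source may have more. Where it says the series, first, only, none or still open, it means among the compounds named here.

Three compounds of the series were measured in an assay on CHO cells for displacement of a labelled ligand from adenosine receptor A3 (Homo sapiens), read by scintillation counting, with a stated time of 45 min, tested at 1 uM, in the presence of a further agent that is not named here; a higher number here means more inhibition at the concentration tested (going by the name of the read-out), a lower number less inhibition:
compound 1 `CCCn1c(=O)[nH]c2nc(-c3ccc(S(=O)(=O)N4CCN(Cc5cccc(C)c5)CC4)cc3)[nH]c2c1=O` gives 17%
compound 2 `CCCn1c(=O)[nH]c2nc(-c3ccc(S(=O)(=O)N4CCN(Cc5cccc(Br)c5)CC4)cc3)[nH]c2c1=O` gives 23%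
compound 3 `CCCn1c(=O)[nH]c2nc(-c3ccc(S(=O)(=O)N4CCN(c5ccc(C)cc5)CC4)cc3)[nH]c2c1=O` gives 25%

Compound 3 holds the highest of the three numbers shown, but its nearest neighbour is reached by a number 2 percentage points higher from compound 2 to compound 3 (within the scatter) and the furthest by a number 8 percentage points higher from compound 1 to compound 3 (within the scatter), both within the scatter, so no order among the three can be claimed. Compound 4 `CCCn1c(=O)[nH]c2nc(-c3ccc(S(=O)(=O)N4CCN(Cc5ccc(Br)cc5)CC4)cc3)[nH]c2c1=O` differs from compound 3 in one place: 4-bromobenzyl in place of 4-methylphenyl on an amine nitrogen in a ring. The measured steps that bear on this change are a number 2 percentage points higher from compound 2 to compound 3 (within the scatter), a number 8 percentage points higher from compound 1 to compound 3 (within the scatter) and a number 6 percentage points higher from compound 1 to compound 2 (within the scatter); none of them leaves the scatter, so no step beyond the scatter is expected in this assay in either direction. Compound 4 is therefore estimated at 22%, within 10% to 35%, which means an expected step of a number 3 percentage points lower from compound 3 to compound 4 (within the scatter).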

Compound 4, a percentage reported as inhibition, at one concentration (the size of the read-out at that concentration, not a potency): 28%
For compound 4 the middle estimate is 6 percentage points below the measured one, within the range that was stated.
By their numbers in this assay, from the lowest: compounds 1, 2, 3 and 4 (each within the scatter of the next, the first and the last beyond it).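

On the ring amine nitrogen, 4-bromobenzyl in place of 4-methylphenyl gives a number 3 percentage points higher from compound 3 to compound 4 (within the scatter), and 4-bromophenyl in place of 3-bromophenyl on the saturated chain carbon gives a number 5 percentage points higher from compound 2 to compound 4 (within the scatter), so neither change separates in this assay. Among these compounds, the first step beyond the scatter in this set is modest, a number 11 percentage points higher from compound 1 to compound 4 (beyond the scatter), and since the steps through compound 2 stay within the scatter, the 3-methylphenyl to 4-bromophenyl change cannot be divided into parts. No measurement in hand gives a cause for these steps. On these data alone, whether a longer chain on the ring nitrogen, or an amine or a carboxylic acid on the phenyl ring, would move the number further stays open.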